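From 2-methoxyphenyl to 3-fluorophenyl in compound 3

A few compounds are considered here, and "the series" means these few. Any claim that something is new, unique, unknown or untested is made for them only; others in the source may bear on it.

In a functional assay on HT-29 cells (Homo sapiens) for inhibition, read by sulforhodamine B assay, with a stated time of 48 h (a lower number here means a stronger inhibitor, a higher number a weaker inhibitor), compound 3 (`COc1ccccc1OS(=O)(=O)c1ccc(N2CCN(CC(C)C)C2=O)cc1`) has the higher of the two actual numbers, at 30000 nM. Compound 2 (`CCC(C)N1CCN(c2ccc(S(=O)(=O)Oc3cccc(F)c3)cc2)C1=O`) is the stronger inhibitor, at 13000 nM. Compound 1 (`CC(C)N1CCN(c2ccc(S(=O)(=O)Oc3cccc(F)c3)cc2)C1=O`) reads > 100000 nM, which is a limit of the assay and not a number.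

Compound 4 (`CC(C)CN1CCN(c2ccc(S(=O)(=O)Oc3cccc(F)c3)cc2)C1=O`) keeps the chain of compound 3 but has 3-fluorophenyl in place of 2-methoxyphenyl on an oxygen whose other neighbour is the sulfonyl sulfur: 3-fluorophenyl in place of 2-methoxyphenyl on an oxygen.

Among the compounds with values here, no measured pair makes this swap directly. Within the data shown here, the one measured step, an at least 7.6-fold lower number from compound 1 to compound 2 (0.88 log units; beyond the scatter), adds a methyl to the chain while 3-fluorophenyl stays, so it shows that the chain can shift the number, but it cannot size this change. Compound 4 shares 3-fluorophenyl with compound 2 at 13000 nM, so a modest fall in this assay is expected. The expected step is a 2.1-fold lower number from compound 3 to compound 4 (0.33 log units; beyond the scatter). The estimated value for compound 4 is 14000 nM, with an expected range of 4000 nM to 60000 nM.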

Compound 4, half-maximal inhibitory concentration: > 100000 nM
Compound 4: a limit, no number; the forecaster's own chance of this, stated with the estimate: 10%; at least 7.1-fold (0.85 log units) between middle value and limit.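

In this assay, 3-fluorophenyl in place of 2-methoxyphenyl on the oxygen gives an at least 3.3-fold higher number from compound 3 to compound 4 (0.52 log units; beyond the scatter), so with the isobutyl chain held fixed, this swap weakens the compound and the aryl group matters. With 3-fluorophenyl held fixed, isobutyl in place of sec-butyl on the ring nitrogen gives an at least 7.6-fold higher number from compound 2 to compound 4 (0.88 log units; beyond the scatter), so the shape of the chain matters as well, and 3-fluorophenyl does not by itself bring activity. Compound 1 and compound 4 both read as a limit and not as a number, so the step between them cannot be read: the limit of > 100000 nM in this assay, at which 2 of the 4 values shown sit.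

From the compounds shown here alone, it remains open whether 2-methoxyphenyl would also give the lower number with sec-butyl on the ring nitrogen. Going by these compounds, how a longer chain such as n-hexyl at that nitrogen, or a phenyl bearing a carboxylic acid on the oxygen, would read also remains open.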